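Swapping one ring on compound 2: a cytotoxicity forecast

A few compounds are considered here, and "the series" means these few. Any claim that something is new, unique, unknown or untested is made for them only; others in the source may bear on it.

Compound 1 `NS(=O)(=O)c1ccc(N2N=C(c3ccccc3)CC2c2ccccc2F)cc1`: 28000 nM
Compound 2 `NS(=O)(=O)c1ccc(N2N=C(c3ccc(OCc4ccccc4)cc3)CC2c2ccc(F)cc2)cc1`: 90000 nM
Compound 3 `Cc1ccc(C2CC(c3ccc(Oc4ccccc4)cc3)=NN2c2ccc(S(N)(=O)=O)cc2)cc1`: 86000 nM

In an ADME assay on Vero 76 cells (Chlorocebus sabaeus) for cytotoxicity, read by MTT assay, with a stated time of 96 h (on this read-out lower numbers stand for higher toxicity in this test and higher numbers for lower toxicity in this test), compound 2 gives 90000 nM. This matches compound 3 at 86000 nM within the usual scatter of repeat measurements. Compound 1, at 28000 nM, has a lower number, and that gap lies beyond the scatter.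

Compound 4 `Cc1cccc(C2CC(c3ccc(OCc4ccccc4)cc3)=NN2c2ccc(S(N)(=O)=O)cc2)c1` keeps the rest of compound 2 but carries 3-methylphenyl in place of 4-fluorophenyl on a saturated ring carbon. For the measured compounds named here, no measured pair of compounds isolates this kind of swap, so the data offer no direct guide to it. The closest evidence is that compound 2 at 90000 nM and compound 3 at 86000 nM lie close together, although they differ in more than one place. In this assay, no change beyond the scatter is therefore expected, and the estimated step is a 1.2-fold lower number from compound 2 to compound 4 (0.08 log units; within the scatter). For compound 4 the estimated value is 75000 nM, with an expected range from 35000 nM to 100000 nM.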

Compound 4, half-maximal cytotoxic concentration: 100000 nM
Beside the measured number, compound 4's estimate is 1.3-fold (0.12 log units) below it, within the range that was stated.
By their numbers in this assay, from the lowest: compound 1; then compounds 3, 2 and 4 (each within the scatter of the next).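

In this assay, the swap of 3-methylphenyl for 4-fluorophenyl on a saturated ring carbon gives a 1.1-fold higher number from compound 2 to compound 4 (0.05 log units; within the scatter). For the compounds shown here, this is the first comparison in which only this position differs, and it shows that, with the rest of compound 2 kept, this exchange of one substituted phenyl ring for another leaves the number within the scatter. The data offer no explanation of why the read-out stays put here.

The swap replaces fluorine with methyl and also changes where the substituent sits on the phenyl ring, so the two changes cannot be separated, and either one alone might behave differently. On these data alone, it also remains open whether a very different group at this carbon, such as a phenyl ring carrying a carboxylic acid or an amine, would stay within the scatter too.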